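This account rests on a few compounds, and the source may have more. Where it says the series, first, only, none or still open, it means among the compounds named here.

Compound 1, `CCn1c(C(=O)NCCCN(C)C)ccc1C(CC)(CC)c1ccc(OCCC(O)(CC)CC)c(C)c1`, gives 2420 nM in an ADME assay on L02 cells (Homo sapiens) for antiproliferative activity, read by MTT assay, with a stated time of 48 h; on this read-out higher numbers stand for weaker inhibition and lower numbers for stronger inhibition. Of the two numbers measured, compound 1 stands highest, and the nearest is compound 2, `CCN(CC)CCNC(=O)c1ccc(C(CC)(CC)c2ccc(OCCC(O)(CC)CC)c(C)c2)n1CC`, which gives 2290 nM; the difference, a 1.1-fold lower number from compound 1 to compound 2 (0.02 log units; within the scatter), is not more than the scatter. Compound 3, `C#CC(C)OC(=O)c1ccc(C(CC)(CC)c2ccc(OCCC(O)(CC)CC)c(C)c2)n1CC`, returns only a limit of this assay, > 50000 nM.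

The unmeasured compound 4, `C#CCCOC(=O)c1ccc(C(CC)(CC)c2ccc(OCCC(O)(CC)CC)c(C)c2)n1CC`, differs from compound 1 by one change: (but-3-yn-1-yl)oxy in place of (3-(dimethylamino)propyl)amino on a carbonyl carbon. The measured steps that bear on this change are an at least 20-fold higher number from compound 1 to compound 3 (1.31 log units; beyond the scatter) and an at least 21-fold higher number from compound 2 to compound 3 (1.33 log units; beyond the scatter). Both are large, both run in the same direction, and both end at the limit of > 50000 nM in this assay, at which 1 of the 3 values shown sits. Compound 4 repeats the same kind of exchange at the same carbonyl carbon, so a large rise in the number, most likely again reaching the limit rather than a finite value, is expected. The expected step, on this reckoning, is a 21-fold higher number from compound 1 to compound 4 (1.32 log units; beyond the scatter). Compound 4 is therefore estimated at 50000 nM, with a range from 20000 nM to 150000 nM.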

Compound 4, half-maximal inhibitory concentration: > 50000 nM
Compound 4 ended at the assay's limit; the forecaster's own chance of this, stated with the estimate: 70%; the middle value lies on the limit itself.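

In this assay, the (but-3-yn-1-yl)oxy group on the carbonyl carbon gives an at least 20-fold higher number from compound 1 to compound 4 (1.31 log units; beyond the scatter), and against the other amide it gives an at least 21-fold higher number from compound 2 to compound 4 (1.33 log units; beyond the scatter). The large rise therefore does not depend on the branched 1-methylprop-2-yn-1-yl group of compound 3, as the unbranched but-3-yn-1-yl group of compound 4 ends at the same place: the limit of > 50000 nM in this assay, at which 2 of the 4 values shown sit. The step from compound 3 to compound 4 cannot be read, as both values are limits, so the two groups cannot be ranked.

Both compounds with oxygen at this carbonyl carbon also carry a triple bond, and both amides also carry a tertiary amine, so the compounds shown do not tell these features apart. On these data alone, a saturated butyl ester, an amide with a plain butyl chain or a carboxylic acid at this carbon remains open.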